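A few compounds are considered here, and "the series" means these few. Any claim that something is new, unique, unknown or untested is made for them only; others in the source may bear on it.

Measured so far in an ADME assay on the whole organism (Rattus norvegicus) for pharmacokinetics; on this read-out lower numbers stand for narrower distribution and higher numbers for wider distribution into tissues
- Compound 1 `CN(c1ncco1)c1cnc(NCc2c(F)ccc3c2CCO3)n2cnnc12` gives 3.1 L/kg
- Compound 2 `Cc1ncccc1-c1cnc(NCc2c(F)ccc3c2CCO3)c2cn[nH]c(=O)c12` gives "not determined" (no result reported)
- Compound 3 `CN(c1ccn(C)n1)c1cnc(NCc2c(F)ccc3c2CCO3)n2cnnc12` gives 3 L/kg

Among the compounds with values here, compound 3 lies within the scatter of compound 1, the only other compound with a number. Compound 4 `O=C1CC2(CC2)CN1c1cnc(NCc2c(F)ccc3c2CCO3)n2cnnc12` is still unmeasured. It differs from compound 3 on an aromatic carbon, where the methyl(1-methyl-1H-pyrazol-3-yl)amino group leaves: a group of 8 heavy atoms (6 carbon, 1 nitrogen, 1 oxygen; one three-membered non-aromatic ring of carbon only, one five-membered non-aromatic ring with 1 hetero atom) in place of a group of 8 heavy atoms (5 carbon, 3 nitrogen; one five-membered aromatic ring with 2 hetero atoms), on an aromatic carbon. Within the data shown here, only one measured step offers a guide, a 1.0-fold lower number from compound 1 to compound 3 (0.01 log units; within the scatter), and it exchanged one aromatic ring for another on a nitrogen. That step stayed within the scatter, but it is a weak guide to this larger change, so no clear direction can be drawn from it. The expected step is a 1.2-fold lower number from compound 3 to compound 4 (0.08 log units; within the scatter), no larger than the scatter. For compound 4 the estimated value in this assay is 2.5 L/kg, with an expected range from 1.2 L/kg to 5 L/kg.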

Compound 4, volume of distribution at steady state: 1.4 L/kg
Compound 4: the middle estimate sits 1.8-fold (0.25 log units) above what was measured, within the range that was stated.
By their numbers in this assay, from the lowest: compound 4; then compounds 3 and 1 (each within the scatter of the next).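

In this assay, the earlier exchange of one aromatic ring for another, on the nitrogen, left the number within the scatter. This position responds more clearly when the whole amino group gives way to a group with no aromatic ring, a carbonyl-bearing five-membered ring joined to a three-membered carbon ring: the result is a 2.1-fold lower number from compound 3 to compound 4 (0.33 log units; beyond the scatter) and a 2.2-fold lower number from compound 1 to compound 4 (0.35 log units; beyond the scatter). Nothing available explains this drop. From the compounds shown here alone, it remains open whether the carbonyl or the missing aromatic ring goes with the lower number, and how a plain amine such as piperidine would read at this aromatic carbon.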